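Phenoxymethyl in place of bromo on the shared core

The compounds below may be only part of what the source reports. "The series", "measured", "known", "first", "only" and "open" are said of these compounds alone.

Measured so far:
compound 1 `O/N=C(/Nc1cccc(Br)c1)c1ccc2occc2c1` — 440 nM
compound 2 `O/N=C(/Nc1ccc(F)c(Br)c1)c1ccc2occc2c1` — 1600 nM
compound 3 `O/N=C(/Nc1ccc(Cl)c(F)c1)c1ccc2occc2c1` — > 30000 nM, which is a limit of the assay and not a number

Three compounds share one core and differ in a single substituent. In an assay on isolated protein for inhibition of Indoleamine 2,3-dioxygenase 1 (Homo sapiens), read by spectrophotometry (on this read-out higher numbers stand for weaker inhibition and lower numbers for stronger inhibition), compound 1 gives 440 nM, the lower of the two numbers; compound 2 sits nearest, with a 3.6-fold higher number from compound 1 to compound 2 (0.56 log units; beyond the scatter). Compound 3 reaches only (the limit of > 30000 nM in this assay, at which 1 of the 3 values shown sits). Compound 4 `O/N=C(/Nc1cccc(COc2ccccc2)c1)c1ccc2occc2c1` changes compound 1 by phenoxymethyl in place of bromo on an aromatic carbon. For the measured compounds named here, the only measured step, a 3.6-fold higher number from compound 1 to compound 2 (0.56 log units; beyond the scatter), exchanges hydrogen for fluoro and says little about trading bromo for a much larger group, so no measured step bears directly on this change. A shift beyond the scatter in either direction is plausible. The expectation for compound 4 is 1500 nM (range 200 nM to 15000 nM), meaning a 3.4-fold higher number from compound 1 to compound 4 (0.53 log units; beyond the scatter).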

Compound 4, half-maximal inhibitory concentration: > 30000 nM
Compound 4: only a limit was reported; the forecaster's own chance of this, stated with the estimate: 10%; middle value at least 20-fold (1.30 log units) away from the limit.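

Phenoxymethyl in place of bromo brings an at least 68-fold higher number from compound 1 to compound 4 (1.83 log units; beyond the scatter), the first sign that the group at this place on the aromatic ring can decide whether any inhibition is seen. In this assay, going by these compounds, compound 4 gives > 30000 nM, a limit and not a number, so the true size of this step stays unknown. Compound 4 is not alone at this ceiling: the limit of > 30000 nM in this assay, at which 2 of the 4 values shown sit.

On these data alone, whether the loss follows the added ring, the oxygen or the longer chain stays open. A methoxy group or a plain phenyl ring in place of bromo would help to separate these.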